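Nitro in place of hydrogen: compound 1 to compound 3

The source may report more compounds than this note shows. Statements on the series, on what has been measured and on what is new or still open speak of the compounds shown alone.

In a functional assay on A549 cells (Homo sapiens) for antiproliferative activity, read by MTT assay, with a stated time of 72 h (a higher number here means a weaker inhibitor, a lower number a stronger inhibitor), compound 1 (`Cc1nc(C)c(/C=C/C(=O)/C=C/c2ccccc2)nc1C`) gives 12300 nM and has a single measured neighbour, compound 2 (`Cc1nc(C)c(/C=C/C(=O)/C=C/c2cccc([N+](=O)[O-])c2)nc1C`) at 6700 nM; the two cannot be ranked against each other. Compound 3 (`Cc1nc(C)c(/C=C/C(=O)/C=C/c2ccc([N+](=O)[O-])cc2)nc1C`) has not been measured. Its difference from compound 1 is nitro in place of hydrogen on an aromatic carbon, here para to a large group.

One measured step bears on this, the same exchange of hydrogen for nitro at the ring position shown in compound 2. Among the compounds with values here, that step is a 1.8-fold lower number from compound 1 to compound 2 (0.26 log units; within the scatter) and is the only guide to the size of the change. Within the data shown here, no measurement yet covers nitro at the place it holds in compound 3, so the guide is indirect. No step beyond the scatter is therefore expected in this assay, and any shift is expected to lean towards a lower number. The estimated change is a 1.6-fold lower number from compound 1 to compound 3 (0.21 log units; within the scatter) and would stay within the scatter. For compound 3 the expected value is 7500 nM with an estimated range from 3000 nM to 17000 nM in this series.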

Compound 3, half-maximal inhibitory concentration: 9600 nM
For compound 3 the middle estimate is 1.3-fold (0.11 log units) below the measured one; measured number inside the range.
By their numbers in this assay, from the lowest: compounds 2, 3 and 1 (each within the scatter of the next).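

In this assay the reading is a 1.3-fold lower number from compound 1 to compound 3 (0.11 log units; within the scatter) for nitro in place of hydrogen on an aromatic carbon, para to a large group, so a second ring position now gives a step that stays inside the scatter. Set beside a 1.8-fold lower number from compound 1 to compound 2 (0.26 log units; within the scatter) in the same assay, this shows that neither placing of nitro separates from compound 1, and compound 2 and compound 3 also lie within the scatter of each other, so the data give no ground for preferring one placing. Nothing available accounts for this flat response or assigns any property to nitro in this series.

As far as these compounds go, it remains open whether a group of another kind at this same position, such as an amine or a carboxylic acid, would give a step beyond the scatter in this assay and thereby show whether this ring position matters at all. Also open, from the compounds shown here alone, is whether a longer chain or another change on the shared core would move the number further than any exchange of hydrogen for nitro has done so far.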